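This account rests on a few compounds, and the source may have more. Where it says the series, first, only, none or still open, it means among the compounds named here.

Measured in a functional assay on HeLa cells (Homo sapiens) for cytotoxicity, read by MTT assay; a higher number here means a weaker inhibitor, a lower number a stronger inhibitor:
- Compound 1 `CCC(CO[C@H](CC=C(C)C)C1=CC(=O)c2c(O)ccc(O)c2C1=O)OC(C)=O`: 44000 nM
- Compound 2 `CC(C)=CC[C@@H](OC(=O)C1CCCCO1)C1=CC(=O)c2c(O)ccc(O)c2C1=O`: > 100000 nM, a limit of the assay
- Compound 3 `CCCCC(C)(O)CC(=O)O[C@H](CC=C(C)C)C1=CC(=O)c2c(O)ccc(O)c2C1=O`: 60600 nM

Among the measured compounds shown here, compound 3 has only one neighbour with a true number, and the two sit close: a 1.4-fold higher number from compound 1 to compound 3 (0.14 log units; within the scatter). The remaining step to it, an at least 1.6-fold lower number from compound 2 to compound 3 (0.21 log units; that floor lies within the scatter), rests on a limit.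

Compound 4 `CCC(O)(CC)CC(=O)O[C@H](CC=C(C)C)C1=CC(=O)c2c(O)ccc(O)c2C1=O` carries 1-ethyl-1-hydroxypropyl in place of 1-hydroxy-1-methylpentyl on a saturated chain carbon bound to a carbonyl carbon.

Among the measured steps, only an at least 2.2-fold higher number from compound 1 to compound 2 (0.35 log units; beyond the scatter) passed the scatter, and it introduced the oxan-2-yl group. Compound 4, like compound 3, has no ring in the group that changes. In this assay the expected change is none beyond the scatter: a 1.1-fold lower number from compound 3 to compound 4 (0.04 log units; within the scatter). The estimated value for compound 4 is 55000 nM, with an expected range of 25000 nM to 100000 nM.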

Compound 4, half-maximal inhibitory concentration: 52000 nM
Compound 4: the middle estimate sits 1.1-fold (0.02 log units) above what was measured; measured number inside the range.
By their numbers in this assay, from the lowest: compounds 1, 4 and 3 (each within the scatter of the next). At a limit, above all of these: compound 2.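

In this assay, 1-ethyl-1-hydroxypropyl in place of 1-hydroxy-1-methylpentyl on a saturated chain carbon bound to a carbonyl carbon gives a 1.2-fold lower number from compound 3 to compound 4 (0.07 log units; within the scatter), so this change of chain leaves no readable effect at this position. The other neighbour with a true number gives a 1.2-fold higher number from compound 1 to compound 4 (0.07 log units; within the scatter), which keeps all three true numbers together. Compound 2 stands at a limit. The remaining step, an at least 1.9-fold lower number from compound 2 to compound 4 (0.28 log units; that floor lies within the scatter), rests on that limit and cannot be read as a true difference: the limit of > 100000 nM in this assay, at which 1 of the 4 values shown sits.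

The compounds shown leave open whether an amine or a carboxylic acid on this chain would move the number beyond the scatter. A phenyl ring in the same place is equally untested here.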